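Taking the bromo off compound 2

The source may report more compounds than this note shows. Statements on the series, on what has been measured and on what is new or still open speak of the compounds shown alone.

Of the compounds shown here, two with a shared core have been measured so far. In a functional assay on HL-60 cells (Homo sapiens) for antiproliferative activity, read by sulforhodamine B assay, with a stated time of 72 h (on this read-out lower numbers stand for stronger inhibition and higher numbers for weaker inhibition), compound 1 `S=C(N/N=C/c1ccc2ccccc2n1)Nc1cccc(Br)c1` gives 53800 nM as its reading, and compound 2 `S=C(N/N=C/c1ccc2ccccc2n1)Nc1ccc(Br)cc1` gives 27500 nM as its reading. Compound 2 therefore stands within the scatter of compound 1, and the two cannot be ranked.

Compound 3 `S=C(N/N=C/c1ccc2ccccc2n1)Nc1ccccc1` has not yet been measured. It differs from compound 2 at a single place, where 4-bromophenyl becomes phenyl: hydrogen in place of bromo on an aromatic carbon with hydrogen in place of bromo on an aromatic carbon.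

Among the measured compounds shown here, no measured step removes a bromo. The nearest evidence is a 2.0-fold lower number from compound 1 to compound 2 (0.29 log units; within the scatter) when the bromo changes its place on the same ring. This single step says little about losing the bromo altogether, so no change beyond the scatter is expected in this assay in either direction. The expected step is a 1.3-fold higher number from compound 2 to compound 3 (0.10 log units; within the scatter) and remains a rough estimate. For compound 3 the estimated value is 35000 nM with an expected range from 14000 nM to 90000 nM for repeated measurements.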

Compound 3, half-maximal inhibitory concentration: 9130 nM
Beside the measured number, compound 3's estimate is 3.8-fold (0.58 log units) above it; the whole stated range lies above it.
By their numbers in this assay, from the lowest: compound 3; then compounds 2 and 1 (each within the scatter of the next).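

In this assay, among the compounds shown here, removing the bromo gives the first change beyond the scatter, seen as a 3.0-fold lower number from compound 2 to compound 3 (0.48 log units; beyond the scatter) and, starting from the other bromo compound, as a 5.9-fold lower number from compound 1 to compound 3 (0.77 log units; beyond the scatter). Moving the bromo around the ring gave no step that could be told from the scatter, whereas replacing it with hydrogen lowers the number from either bromo compound, which makes compound 3 the strongest inhibitor of the three on this read-out. Nothing on hand accounts for this change, so the step records its direction and size but not its reason.

On these data alone, what a fluoro, a methoxy group, an amine or a carboxylic acid would do on the same aromatic carbon remains open, so it cannot yet be said whether hydrogen is the best choice there or only better than bromo. All three readings also come from this assay, which leaves open whether the same step would appear in a different assay.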